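This account rests on a few compounds, and the source may have more. Where it says the series, first, only, none or still open, it means among the compounds named here.

Three compounds sharing one core, each carrying the same cinnamamide side chain type, set the scene. Compound 1 `Nc1cc(C2CCCC2)nc2ccc(NC(=O)/C=C/c3ccc(C(F)(F)F)cc3)cc12` bears a free amine and a cyclopentyl group; in an assay on isolated protein for displacement of a labelled ligand from melanin-concentrating hormone receptor 1 (Homo sapiens) (on this read-out lower numbers stand for stronger inhibition and higher numbers for weaker inhibition), compound 1 gives 0.8 nM. Compound 3 `CCCc1cc(N)c2cc(NC(=O)/C=C/c3ccc(C(C)C)cc3)ccc2n1` also bears a free amine, together with a propyl chain and an isopropyl group in place of the trifluoromethyl; in this assay compound 3 gives 2.9 nM. Compound 2 `CCCc1cc(NC2CC2)c2cc(NC(=O)/C=C/c3ccc(C(F)(F)F)cc3)ccc2n1` carries a cyclopropyl group on the amine nitrogen; in this assay compound 2 gives 40 nM, the highest of the three numbers, separated from compound 3 by a gap beyond the scatter and from compound 1 by a still larger one.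

Compound 4 `CCCc1cc(NC)c2cc(NC(=O)/C=C/c3ccc(C(F)(F)F)cc3)ccc2n1` takes the next step: methyl in place of cyclopropyl on a nitrogen on an aromatic ring. Within the data shown here, no measured pair isolates this single change. Both compounds with an unsubstituted amine, compound 1 at 0.8 nM and compound 3 at 2.9 nM, sit far below compound 2, and the methyl group stands between the cyclopropyl and the free amine in what is counted. The expected step is therefore a 4.0-fold lower number from compound 2 to compound 4 (0.60 log units; beyond the scatter), a decrease beyond the scatter, though not reaching the level of compound 3. Compound 4 is accordingly estimated at 10 nM, within a range from 3 nM to 35 nM.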

Compound 4, half-maximal inhibitory concentration: 1.5 nM
Compound 4: middle estimate off by 6.7-fold (0.82 log units), on the high side; the measured number lies below the stated range.
By their numbers in this assay, from the lowest: compounds 1, 4 and 3 (each within the scatter of the next, the first and the last beyond it); then compound 2.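

Among these compounds, the pair of compound 2 and compound 4 gives the first comparison here that differs in one place only: in this assay, methyl in place of cyclopropyl on a nitrogen on an aromatic ring brings a 27-fold lower number from compound 2 to compound 4 (1.43 log units; beyond the scatter), a large step beyond the scatter. With the propyl chain, the trifluoromethyl group and the rest of the molecule unchanged, this shows that the group on this nitrogen can by itself move the number by this much, and that a substituent here does not as such rule out a low number, so the high number of compound 2 goes with the cyclopropyl rather than with substitution on this nitrogen in general. No measured information is available that would explain the size of this step.

On these data alone, it remains open whether the step follows the number of carbons or the presence of the ring, which an ethyl or a cyclobutyl group on this nitrogen would help to tell apart. The compounds shown also leave open how the free amine compares on exactly this background, and whether the same change holds with a cyclopentyl group in place of the propyl chain.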